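Aryl swap on the aromatic nitrogen of the shared core

A few compounds are considered here, and "the series" means these few. Any claim that something is new, unique, unknown or untested is made for them only; others in the source may bear on it.

Compound 2 `Cc1cc(=O)n(-c2ccccc2OC(F)(F)F)nc1C(=O)Nc1ccc(Oc2ncnc3sccc23)c(F)c1` stands at a limit: in a functional assay on HepG2 cells (Homo sapiens) for cytotoxicity, read by MTT assay, with a stated time of 72 h (a higher number here means a weaker inhibitor, a lower number a stronger inhibitor), compound 2 gives > 40000 nM, a limit of the assay and not a number. Compound 1 `Cc1cc(=O)n(-c2ccc(Br)cc2F)nc1C(=O)Nc1ccc(Oc2ncnc3sccc23)c(F)c1` gives 13800 nM in this assay. Among the compounds with values here, the single measured step, an at least 2.8-fold higher number from compound 1 to compound 2 (0.46 log units; beyond the scatter), is the one that bears here, and it ends at the limit of > 40000 nM in this assay, at which 1 of the 2 values shown sits. Compound 3 `Cc1cc(=O)n(-c2ccc(F)cc2)nc1C(=O)Nc1ccc(Oc2ncnc3sccc23)c(F)c1` differs from compound 2 by 4-fluorophenyl in place of 2-(trifluoromethoxy)phenyl on an aromatic nitrogen. The incoming 4-fluorophenyl resembles the aryl of compound 1 more closely than the group it replaces. A partial reversal of that step is therefore expected, an at least 1.6-fold lower number from compound 2 to compound 3 (0.20 log units; that floor lies within the scatter). Compound 3 is estimated at 25000 nM, within 8000 nM to 60000 nM.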

Compound 3, half-maximal inhibitory concentration: 12500 nM
Compound 3: middle estimate off by 2.0-fold (0.30 log units), on the high side, and the stated range covers the measured number.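

On the aromatic nitrogen, 4-fluorophenyl in place of 2-(trifluoromethoxy)phenyl gives an at least 3.2-fold lower number from compound 2 to compound 3 (0.50 log units; beyond the scatter) in this assay. That step is only a floor, compound 2 standing at a limit of the assay: the limit of > 40000 nM in this assay, at which 1 of the 3 values shown sits. Against 4-bromo-2-fluorophenyl, 4-fluorophenyl gives a 1.1-fold lower number from compound 1 to compound 3 (0.04 log units; within the scatter), so among these three aryl groups only 2-(trifluoromethoxy)phenyl stands apart.

Going by these compounds, whether the trifluoromethoxy group itself sets compound 2 apart remains open. So does the reading of an unsubstituted phenyl, or of a phenyl carrying an amine or a carboxylic acid, on this nitrogen.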